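The source may report more compounds than this note shows. Statements on the series, on what has been measured and on what is new or still open speak of the compounds shown alone.

Compound 2 `Cc1cnc(-c2ccccc2C(C)C)nc1NCC1CCN(c2cnccn2)CC1` gives 140 nM in an assay on a protein complex for inhibition of ubiquitin carboxyl-terminal hydrolase 1/WD repeat-containing protein 48 (Homo sapiens), read by fluorescence; on this read-out higher numbers stand for weaker inhibition and lower numbers for stronger inhibition. Compound 1 `COc1ccc(CNc2nc(-c3ccccc3C(F)(F)F)nc3ccccc23)cc1` gives 6200 nM in this assay. Compound 2 therefore stands with the lowest number of the two, and the gap to compound 1 is well beyond the scatter; the two structures differ in several places at once, so no single change can be read from that gap.

Compound 3 `Cc1ccc(N2CCC(CNc3nc(-c4ccccc4C(C)C)ncc3C)CC2)cn1` has not yet been measured. It differs from compound 2 by 6-methylpyridin-3-yl in place of pyrazin-2-yl on an amine nitrogen in a ring. For the measured compounds named here, no measured pair differs in one place, so the size of this step has no measured counterpart in the set. The change keeps a six-membered aromatic ring on the amine nitrogen in a ring, and the step is expected to be small, within the scatter or a little beyond, with no firm direction. For compound 3 the estimate in this assay is 150 nM with a range from 50 nM to 450 nM. The expected step is a 1.1-fold higher number from compound 2 to compound 3 (0.03 log units; within the scatter).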

Compound 3, half-maximal inhibitory concentration: 90 nM
Compound 3: middle estimate off by 1.7-fold (0.22 log units), on the high side, and the stated range covers the measured number.
By their numbers in this assay, from the lowest: compounds 3 and 2 (each within the scatter of the next); then compound 1.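

For the compounds shown here, this is the first one-place step: in this assay, 6-methylpyridin-3-yl in place of pyrazin-2-yl on the amine nitrogen in a ring gives a 1.6-fold lower number from compound 2 to compound 3 (0.19 log units; within the scatter), so the two compounds cannot be told apart in this assay. Going by these compounds alone, at this position, a six-membered aromatic ring with 1 hetero atom and a methyl group therefore reads the same as one with 2 hetero atoms and no methyl group, although the single step changes both features together and cannot separate them. Nothing at hand explains the outcome.

Open, as far as these compounds go, is whether plain pyridin-3-yl would read the same, which would isolate the contribution of the methyl group. Also open, from the compounds shown here alone, is how a non-aromatic group on this amine nitrogen, such as acetyl, or an aromatic ring carrying a carboxylic acid, would read.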